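Aryl versus alkyl ether on the pyridine oxygen

The source may hold more compounds than are shown below. What is called first, only, known or untested is meant among the compounds shown, and "the series" means these compounds.

Compounds measured so far:
Compound 1, `FC(F)(F)c1cnc(N2CCC(NC(=S)Nc3cccnc3)CC2)c(Cl)c1`: 1100 nM
Compound 2, `FC(F)(F)Oc1ccc(Oc2ccnc(N3CCC(NC(=S)Nc4cccnc4)CC3)c2)cc1`: 410 nM
Compound 3, `S=C(Nc1cccnc1)NC1CCN(c2cc(OCC3CC3)ccn2)CC1`: 4700 nM

All three were tested in an assay on membranes from brain for binding affinity to Lysophosphatidylserine lipase ABHD12 (Mus musculus), read by fluorescence, with a stated time of 20 min; a lower number here means a stronger inhibitor, a higher number a weaker inhibitor. Compound 3 gives the highest number of the three; the nearest is compound 1, and the furthest is compound 2, both steps lying beyond the scatter, so compound 3 is the weakest inhibitor of the set as it stands.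

The unmeasured compound 4, `S=C(Nc1cccnc1)NC1CCN(c2cc(Oc3ccccc3)ccn2)CC1`, differs from compound 3 in one place: phenyl in place of cyclopropylmethyl on an oxygen on an aromatic ring.

Going by the values given here, the only step in the data that bears on this change is an 11-fold higher number from compound 2 to compound 3 (1.06 log units; beyond the scatter), where an aryl ether on that oxygen was replaced by the cyclopropylmethyl group. Compound 4 goes back toward an aryl ether, though without the trifluoromethoxy substituent that compound 2 carries. The expectation is therefore a step down in this assay, smaller than the full step seen from compound 2 to compound 3, since the phenyl of compound 4 is a plainer group than the aryl ether of compound 2.

Compound 4 is expected to give 1300 nM, with a plausible range from 450 nM to 3800 nM, which means an expected step of a 3.6-fold lower number from compound 3 to compound 4 (0.56 log units; beyond the scatter).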

Compound 4, half-maximal inhibitory concentration: 1900 nM
Beside the measured number, compound 4's estimate is 1.5-fold (0.16 log units) below it; low and high end bracket the measured number.
By their numbers in this assay, from the lowest: compound 2; then compounds 1 and 4 (each within the scatter of the next); then compound 3.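

In this assay there is a 2.5-fold lower number from compound 3 to compound 4 (0.39 log units; beyond the scatter) when phenyl replaces cyclopropylmethyl, so the bare aromatic ring on this oxygen already counts, with no substituent of its own. The trifluoromethoxy group counts as well, with a 4.6-fold higher number from compound 2 to compound 4 (0.67 log units; beyond the scatter) when hydrogen takes its place on an aromatic carbon. The large step seen earlier, an 11-fold higher number from compound 2 to compound 3 (1.06 log units; beyond the scatter), therefore splits into two parts, each beyond the scatter: one belongs to the change from cyclopropylmethyl to phenyl, the other to the trifluoromethoxy group on that phenyl.

Still open, from the compounds shown here alone, is whether a chlorine, a methoxy group or a nitrile on the phenyl ring could do what trifluoromethoxy does, or whether that gain is particular to this one group. Equally open, going by these compounds, is how a benzyl group or a longer chain on the oxygen would compare with phenyl and cyclopropylmethyl, which would show whether an aromatic ring is needed there at all. Nothing in the available data explains why either change shifts the number in this way.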